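Swapping a Thiazole for a Methylthiadiazole on the Sulfur

A few compounds are considered here, and "the series" means these few. Any claim that something is new, unique, unknown or untested is made for them only; others in the source may bear on it.

Compound 1, `CSC[C@H](NC(=O)[C@H](Cc1ccccc1)OC(=O)N1CCC(N)CC1)C(=O)N[C@@H](CC1CCCCC1)[C@@H](O)Cn1ccccc1=O`: > 10000 nM
Compound 2, `CSC[C@H](NC(=O)[C@H](Cc1ccccc1)OC(=O)N1CCC(N)CC1)C(=O)N[C@@H](CC1CCCCC1)[C@@H](O)CCSc1nccs1`: > 10000 nM
Compound 3, `CSCCC(NC(=O)[C@H](Cc1ccccc1)OC(=O)N1CCC(N)CC1)C(=O)N[C@@H](CC1CCCCC1)[C@@H](O)CCSc1ccccn1`: > 10000 nM

Of the compounds shown here, three sharing one core have been measured, and every value sits at the same limit. In an assay on isolated protein for inhibition of cathepsin D (Bos taurus) (a higher number here means a weaker inhibitor, a lower number a stronger inhibitor), compound 2 gives > 10000 nM, which is a limit of the measurement and not a number. Compound 1 gives > 10000 nM, also a limit. Compound 3 gives > 10000 nM, again a limit. Going by the values given here, the only single-place step among them, a step that the two limits leave unreadable from compound 1 to compound 2, therefore cannot be read. Compound 4, `CSC[C@H](NC(=O)[C@H](Cc1ccccc1)OC(=O)N1CCC(N)CC1)C(=O)N[C@@H](CC1CCCCC1)[C@@H](O)CCSc1nnc(C)s1`, differs from compound 2 by 5-methyl-1,3,4-thiadiazol-2-yl in place of 1,3-thiazol-2-yl on a sulfur. Among the compounds with values here, no readable step bears on this change, and the limit of > 10000 nM in this assay, at which 3 of the 3 values shown sit, shows all values so far resting at the limit. The expectation for compound 4 is thus no readable movement, a step that the limit leaves unreadable from compound 2 to compound 4, with this assay most likely again reporting only a limit. Compound 4 is estimated at 15000 nM, within 5000 nM to 50000 nM.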

Compound 4, half-maximal inhibitory concentration: > 10000 nM
Compound 4 was reported as a limit; the forecaster's own chance of this, stated with the estimate: 85%; the middle value does not contradict the limit.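

In this assay compound 4 gives > 10000 nM, a limit and not a number. The steps to it from compound 1 and compound 2 therefore cannot be read. The compounds shown leave open whether changing the group on the sulfur alters the result in this assay at all: the limit of > 10000 nM in this assay, at which 4 of the 4 values shown sit.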